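The source may hold more compounds than are shown below. What is called first, only, known or untested is meant among the compounds shown, and "the series" means these compounds.

Among the compounds with values here, compound 3 `Nc1ncnn2c([C@@H]3O[C@H](CO)[C@@H](O)[C@H]3O)cc(C#Cc3ccccc3)c12` gives 88000 nM in a functional assay on LN-229 cells (Homo sapiens) for antiproliferative activity, with a stated time of 72 h (on this read-out lower numbers stand for stronger inhibition and higher numbers for weaker inhibition), the highest of the three numbers measured so far; compound 1 `CCCC#Cc1cc([C@@H]2O[C@H](CO)[C@@H](O)[C@H]2O)n2ncnc(N)c12` gives 40 nM and compound 2 `Nc1ncnn2c([C@@H]3O[C@H](CO)[C@@H](O)[C@H]3O)cc(C#CC3CC3)c12` gives 30 nM. The step from compound 3 to compound 4 `Cc1ccccc1-c1cc([C@@H]2O[C@H](CO)[C@@H](O)[C@H]2O)n2ncnc(N)c12` is 2-methylphenyl in place of 2-phenylethynyl on an aromatic carbon. Within the data shown here, no measured step removes the triple bond, so the only steps bearing on it are a 2200-fold higher number from compound 1 to compound 3 (3.34 log units; beyond the scatter) and a 2900-fold higher number from compound 2 to compound 3 (3.47 log units; beyond the scatter), both large, both turning on phenyl in place of propyl or cyclopropyl on the triple-bonded carbon. Compound 4 keeps an aromatic ring but not the triple bond, so a step of a 4.4-fold lower number from compound 3 to compound 4 (0.64 log units; beyond the scatter) is expected, with wide uncertainty. Compound 4 is estimated at 20000 nM, in a range from 2000 nM to 100000 nM.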

Compound 4, half-maximal inhibitory concentration: > 100000 nM
Compound 4: a limit, no number (the forecaster's own chance of this, stated with the estimate: 25%); at least 5.0-fold (0.69 log units) between middle value and limit.
By their numbers in this assay, from the lowest: compounds 2 and 1 (each within the scatter of the next); then compound 3. At a limit, above all of these: compound 4.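

In this assay compound 4 gives a limit of the assay and not a number: the limit of > 100000 nM in this assay, at which 1 of the 4 values shown sits. With 2-methylphenyl in place of 2-cyclopropylethynyl, the step is large, with an at least 3300-fold higher number from compound 2 to compound 4 (3.52 log units; beyond the scatter). With 2-methylphenyl in place of pent-1-yn-1-yl, the step is also large, with an at least 2500-fold higher number from compound 1 to compound 4 (3.39 log units; beyond the scatter). A carbon-only aromatic ring on this aromatic carbon goes with weak inhibition in both compound 3 and compound 4, with or without the triple bond. As far as these compounds go, with 2-methylphenyl in place of 2-phenylethynyl, there is an at least 1.1-fold higher number from compound 3 to compound 4 (0.05 log units; that floor lies within the scatter), a floor that lies within the scatter, so the true size of this step remains unknown.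

From the compounds shown here alone, whether the triple bond itself is needed stays open. A saturated propyl chain or an amine on this carbon would bear on that.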